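The source may report more compounds than this note shows. Statements on the series, on what has been measured and on what is new or still open speak of the compounds shown alone.

Of the compounds shown here, two built on one shared core have so far been measured in a functional assay on MDA-MB-231 cells (Homo sapiens) for antiproliferative activity, read by MTT assay, with stated times of 72 h and 4 h; on this read-out higher numbers stand for weaker inhibition and lower numbers for stronger inhibition. Compound 1 `CS(=O)(=O)c1ccc(C(=O)Nc2ccc(Cl)c(-c3nnc4c(Cl)cccn34)c2)c(Cl)c1` gives 37200 nM in this assay. Compound 2 `O=C(Nc1ccc(Cl)c(-c2nnc3c(Cl)cccn23)c1)c1cccnc1Cl` gives 89700 nM in this assay. Of the two numbers, compound 2 holds the higher one, and its gap to compound 1 lies beyond the usual scatter of repeated measurements of this kind.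

Compound 3 `O=C(Nc1ccc(Cl)c(-c2nnc3c(Cl)cccn23)c1)c1ccccc1Cl` has not yet been measured. It differs from compound 2 in a single place: 2-chlorophenyl in place of 2-chloropyridin-3-yl on a carbonyl carbon. For the measured compounds named here, no pair of measured compounds shows this same change, so the data offer no step from which its size could be read. With no guide of that kind, the expected step of a 1.3-fold lower number from compound 2 to compound 3 (0.11 log units; within the scatter) is set small, in no clear direction beyond the scatter. For compound 3 the estimate in this assay is 70000 nM, with a range from 25000 nM to 200000 nM. The estimate sits near the weak end of the measured numbers because compound 2 gives 89700 nM.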

Compound 3, half-maximal inhibitory concentration: 59900 nM
Compound 3: the middle estimate sits 1.2-fold (0.07 log units) above what was measured; low and high end bracket the measured number.
By their numbers in this assay, from the lowest: compounds 1, 3 and 2 (each within the scatter of the next, the first and the last beyond it).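

In this assay, for the compounds shown here, the step for 2-chlorophenyl in place of 2-chloropyridin-3-yl on a carbonyl carbon is the first reading of this change (a 1.5-fold lower number from compound 2 to compound 3 (0.18 log units; within the scatter)), and it shows that trading this ring for one of carbon only, with one hydrogen-bond acceptor fewer by the count, does not move the number beyond the scatter. Going by these compounds alone, compound 3 also gives the first single-place reading of the methylsulfonyl group, since hydrogen in place of methylsulfonyl on an aromatic carbon likewise stays within the scatter (a 1.6-fold higher number from compound 1 to compound 3 (0.21 log units; within the scatter)), so compound 3 links compound 1 and compound 2 by two small steps although those two stand apart by more than the scatter. Nothing measured here speaks to the reason for these numbers.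

All three compounds shown keep a chlorine-bearing six-membered aromatic ring on the carbonyl carbon, so it remains open whether a cyclohexyl ring or an unsubstituted phenyl ring there would give a larger step. As far as these compounds go, it also remains open whether an amine or a carboxylic acid in place of methylsulfonyl on that aromatic carbon would move the number beyond the scatter.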